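A Fused Ring Replaces the Fluorophenyl Group

The source may report more compounds than this note shows. Statements on the series, on what has been measured and on what is new or still open speak of the compounds shown alone.

Values in a functional assay on A-375 cells (Homo sapiens) for activation, with a stated time of 3 days; on this read-out lower numbers stand for an effect already at smaller amounts and higher numbers for an effect only at larger amounts of compound:
- Compound 1 `O=C(NC1CCCN(Cc2ccc(F)c(F)c2)C1)c1ccc(-c2cscn2)cc1`: > 20000 nM (a limit of the assay, not a number)
- Compound 2 `O=C(Nc1ccc2scnc2c1)C1CCCN(Cc2ccc(F)c(F)c2)C1`: > 20000 nM (a limit of the assay, not a number)
- Compound 3 `O=C(Nc1ccc(-c2cscn2)cc1)C1CCCN(Cc2ccc(F)cc2)C1`: 5000 nM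

Of these three compounds, only compound 3 has an actual number. Beside it stands (the limit of > 20000 nM in this assay, at which 2 of the 3 values shown sit). That leaves compound 3 as the single numerical starting point for the next step.

Compound 4 `O=C(Nc1ccc(-c2cscn2)cc1)C1CCCN(Cc2ccc3cn[nH]c3c2)C1` keeps the core of compound 3 and changes one group: 1H-indazol-6-yl in place of 4-fluorophenyl on a saturated chain carbon bound to an amine nitrogen in a ring. In plain words, 1H-indazol-6-yl takes the place of 4-fluorophenyl on a saturated chain carbon bound to an amine nitrogen in a ring. Put another way, 4-fluorobenzyl becomes (1H-indazol-6-yl)methyl.

Among the measured compounds shown here, no pair of measured compounds shows what a change at this place does, so any forecast is uncertain. A modest shift toward a lower number is expected, and the estimated size is a 2.0-fold lower number from compound 3 to compound 4 (0.30 log units; within the scatter), which may not prove to lie beyond the usual scatter. This expectation rests on compound 3 at 5000 nM alone, so the range is kept wide. A limit result remains possible. The estimated value for compound 4 is 2500 nM, with an expected range from 400 nM to 15000 nM.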

Compound 4, half-maximal effective concentration: > 20000 nM
Compound 4 gave a limit, no number (the forecaster's own chance of this, stated with the estimate: 25%); middle value at least 8.0-fold (0.90 log units) from the limit.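

Swapping 4-fluorophenyl for 1H-indazol-6-yl, on a saturated chain carbon bound to an amine nitrogen in a ring, gives an at least 4.0-fold higher number from compound 3 to compound 4 (0.60 log units; beyond the scatter) in this assay, so the read-out depends on the group at this place, which no earlier pair of compounds could show. Compound 4 gives > 20000 nM, which is a limit of the assay and not a number. The full size of the step therefore stays unknown because the measurement ends at a limit: the limit of > 20000 nM in this assay, at which 3 of the 4 values shown sit.

The change also alters several things at once: the fluorine leaves, a five-membered aromatic ring with 2 hetero atoms enters, and 1 hydrogen-bond donor and 1 hydrogen-bond acceptor come with it, so these compounds cannot say which of these differences matters. On these data alone, whether a plain phenyl group, a pyridine ring or a benzyl group carrying a methoxy substituent at this place would give a number, rather than a limit, remains open.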